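Swapping Pyridine Attachment on a Ring Nitrogen Substituent

A few compounds are considered here, and "the series" means these few. Any claim that something is new, unique, unknown or untested is made for them only; others in the source may bear on it.

Compound 1 `CCCCNc1nc(N)nc2c1CN(S(C)(=O)=O)CC2` gives 9.9 uM in an assay on HEK293 cells for agonist activity at Toll-like receptor 8 (Homo sapiens), read by a luciferase reporter, with a stated time of 6 h; on this read-out lower numbers stand for an effect already at smaller amounts and higher numbers for an effect only at larger amounts of compound.
Compound 2 `CCCCNc1nc(N)nc2c1CN(Cc1cc(F)cc(F)c1)CC2` gives 0.23 uM in this assay.
Compound 3 `CCCCNc1nc(N)nc2c1CN(Cc1cccnc1)CC2` gives 0.13 uM in this assay.

Compound 3 has the lowest of the three numbers in this assay, though its gap to compound 2 is within the scatter, so the two cannot be ranked. The step of a 76-fold lower number from compound 1 to compound 3 (1.88 log units; beyond the scatter) is the only large one seen, while a 1.8-fold lower number from compound 2 to compound 3 (0.25 log units; within the scatter) shows that exchanging one aromatic group for another on this saturated chain carbon changed little.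

Compound 4 `CCCCNc1nc(N)nc2c1CN(Cc1ccncc1)CC2` differs from compound 3 by pyridin-4-yl in place of pyridin-3-yl on a saturated chain carbon bound to an amine nitrogen in a ring. Among the compounds with values here, no measured step covers this exact rearrangement. The closest guide is the small step of a 1.8-fold lower number from compound 2 to compound 3 (0.25 log units; within the scatter), where a different aromatic group at the same place left the number within the scatter. A similar outcome is expected here, with a 1.5-fold higher number from compound 3 to compound 4 (0.19 log units; within the scatter) the estimated step, most likely no change beyond the scatter. Compound 4 is therefore expected to give about 0.2 uM in this assay, within a range from 0.06 uM to 0.7 uM.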

Compound 4, minimum effective concentration: 0.29 uM
The estimate for compound 4 lay 1.5-fold (0.16 log units) below the measured number, and the stated range covers the measured number.
By their numbers in this assay, from the lowest: compounds 3, 2 and 4 (each within the scatter of the next, the first and the last beyond it); then compound 1.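

Exchanging pyridin-3-yl for pyridin-4-yl gives a 2.2-fold higher number from compound 3 to compound 4 (0.35 log units; beyond the scatter), so in this assay this position responds, though only modestly, to a rearrangement of the ring that leaves its atoms unchanged. Against the other aromatic group, the step is a 1.3-fold higher number from compound 2 to compound 4 (0.10 log units; within the scatter), so pyridin-4-yl and 3,5-difluorophenyl cannot be ranked here. The much larger change remains the one away from methylsulfonyl, a 34-fold lower number from compound 1 to compound 4 (1.53 log units; beyond the scatter), which shows that (pyridin-4-yl)methyl, like (pyridin-3-yl)methyl, gives a large drop in the number.

Nothing measured here offers a reason for these differences. From the compounds shown here alone, it also remains open how a pyridin-2-yl group, an unsubstituted phenyl group or a longer chain between the aromatic ring and the ring nitrogen would read in this assay.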